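A few compounds are considered here, and "the series" means these few. Any claim that something is new, unique, unknown or untested is made for them only; others in the source may bear on it.

Four analogues share a nitrone-bearing core. In a functional assay on THP-1 cells (Homo sapiens) for inhibition, read by ELISA, with stated times of 2 h and 48 h (on this read-out lower numbers stand for stronger inhibition and higher numbers for weaker inhibition), compound 1 `COc1ccc(-n2cc(/C=[N+](\[O-])Cc3ccccc3)nn2)cc1` gives 17300 nM. Compound 3 `COc1ccc(-n2cc(/C=[N+](\[O-])C(C)(C)C)nn2)cc1` gives 13500 nM in this assay; the change from compound 1 is tert-butyl in place of benzyl on a double-bonded nitrogen, and the step is a 1.3-fold lower number from compound 1 to compound 3 (0.11 log units; within the scatter). Compound 2 `CCCCCCCCn1cc(/C=[N+](\[O-])Cc2ccccc2)nn1` gives 13100 nM in this assay; the difference between the cores of compound 1 and compound 2 is not broken down here, and the two values lie within the scatter of each other. Compound 4 `CCCCCCCCn1cc(/C=[N+](\[O-])C(C)(C)C)nn1` has not yet been measured; it carries the same change as before, (tert-butyl in place of benzyl on a double-bonded nitrogen), on the core of compound 2. The earlier step of a 1.3-fold lower number from compound 1 to compound 3 (0.11 log units; within the scatter) stayed within the scatter. On that basis the step of a 1.2-fold lower number from compound 2 to compound 4 (0.08 log units; within the scatter) is expected. Compound 4 is therefore estimated to give 11000 nM in this assay, with a range from 5500 nM to 22000 nM.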

Compound 4, half-maximal inhibitory concentration: 7900 nM
For compound 4 the middle estimate is 1.4-fold (0.14 log units) above the measured one; the measured number falls inside the stated range.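

In this assay, tert-butyl in place of benzyl on a double-bonded nitrogen gives a 1.7-fold lower number from compound 2 to compound 4 (0.22 log units; within the scatter), and the two readings of this change agree: the same change on two cores in this assay, a 1.3-fold lower number (0.11 log units; within the scatter) from compound 1 to compound 3 and a 1.7-fold lower number (0.22 log units; within the scatter) from compound 2 to compound 4, 1.3-fold (0.11 log units) apart, within the scatter of two such steps. The change therefore carries from the core of compound 1 to the core of compound 2 with no detectable difference in step size. Each step lies within the scatter on its own, however, so neither core shows a firm effect of the change on inhibition, and two cores do not establish a rule for the series.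

Going by these compounds, whether another group on that nitrogen, such as an amine-bearing chain or a carboxylic acid, would move the number beyond the scatter stays open. On these data alone, the size of the step on any third core also stays open.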